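A few compounds are considered here, and "the series" means these few. Any claim that something is new, unique, unknown or untested is made for them only; others in the source may bear on it.

Working notes on the series. In a functional assay on MCF7 cells (Homo sapiens) for cytotoxicity, read by sulforhodamine B assay, with a stated time of 24 h (a higher number here means a weaker inhibitor, a lower number a stronger inhibitor), compound 1 (`N#CCC(=O)N/N=C1\C(=O)Nc2ccc(S(=O)(=O)N3CCOCC3)cc21`) gives 27700 nM, and compound 2 (`O=C1Nc2ccc(S(=O)(=O)N3CCOCC3)cc2/C1=N/c1cccc(C(F)(F)F)c1`) gives 41100 nM. These two numbers lie within the scatter of each other, so compound 2 has no separate standing from compound 1. Compound 3 (`O=C1Nc2ccc(S(=O)(=O)N3CCOCC3)cc2/C1=N/NC(=O)c1ccccc1`) is the next to read: benzamido in place of 3-(trifluoromethyl)phenyl on a double-bonded nitrogen. In words, benzamido stands in place of 3-(trifluoromethyl)phenyl on a double-bonded nitrogen. Among the measured compounds shown here, one measured step bears on this, since it exchanges a group at that same place: a 1.5-fold higher number from compound 1 to compound 2 (0.17 log units; within the scatter). That exchange stayed within the scatter, and an amide-type group like the benzamido of compound 3 is already present in compound 1 at 27700 nM. No step beyond the scatter is therefore expected in this assay, and the estimated step is a 1.4-fold lower number from compound 2 to compound 3 (0.14 log units; within the scatter). The estimated value for compound 3 is 30000 nM, with an expected range of 12000 nM to 70000 nM.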

Compound 3, half-maximal inhibitory concentration: 414000 nM
The estimate for compound 3 lay 14-fold (1.14 log units) below the measured number, outside the stated range (above it).
By their numbers in this assay, from the lowest: compounds 1 and 2 (each within the scatter of the next); then compound 3.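

In this assay the place on the double-bonded nitrogen is not indifferent to exchange, as the earlier pair within the scatter might have suggested: benzamido in place of 3-(trifluoromethyl)phenyl gives a 10-fold higher number from compound 2 to compound 3 (1.00 log units; beyond the scatter). Compound 1 and compound 3 both carry an amide-type group at this place, yet phenyl in place of cyanomethyl on a carbonyl carbon gives a 15-fold higher number from compound 1 to compound 3 (1.17 log units; beyond the scatter), so the amide-type group alone does not set the number and the group on that carbonyl carbon matters. No measurement shown accounts for either step.

Still open, as far as these compounds go, is whether the higher number belongs to the phenyl on the carbonyl carbon or to phenyl groups there in general. A methyl or a benzyl on that carbon, or a benzamido carrying a hydroxyl or an amine, would separate these readings.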